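Swapping the Difluoronitrophenyl Group at the Limit of Detection

A few compounds are considered here, and "the series" means these few. Any claim that something is new, unique, unknown or untested is made for them only; others in the source may bear on it.

In a functional assay on CCRF-CEM cells (Homo sapiens) for cytotoxicity, in the absence of a further agent (on this read-out lower numbers stand for stronger inhibition and higher numbers for weaker inhibition), compound 1 `COC(=O)c1ccc(CN(CCCc2c(N)nc(N)nc2O)c2cc(F)c(F)cc2[N+](=O)[O-])cc1` gives 59000 nM. Compound 2 `Nc1nc(N)c(CCCN(Cc2ccc(NC(CCC(=O)O)C(=O)O)cc2)c2cc(F)c(F)cc2[N+](=O)[O-])c(O)n1` gives only a limit, > 100000 nM, and not a number. Its place on the scale is therefore at the limit of > 100000 nM in this assay, at which 1 of the 2 values shown sits.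

Compound 3 `Nc1nc(N)c(CCCN(Cc2ccc(NC(CCC(=O)O)C(=O)O)cc2)c2ccc([N+](=O)[O-])c(F)c2F)c(O)n1` has the same atoms as compound 2, joined differently, with 2,3-difluoro-4-nitrophenyl in place of 4,5-difluoro-2-nitrophenyl on an amine nitrogen.

For the measured compounds named here, only one measured step is available, an at least 1.6-fold higher number from compound 1 to compound 2 (0.22 log units; that floor lies within the scatter). Its floor lies within the scatter, and it concerns (1,3-dicarboxypropyl)amino in place of methoxycarbonyl on an aromatic carbon, not the group exchanged here. Going by the values given here, no measured step shows what this exchange does, so the evidence bears on it only indirectly, and no shift beyond the scatter is expected in this assay. The likeliest outcome is that compound 3 is again reported only as a limit.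

The expected change is a number no higher from compound 2 to compound 3 (the limit leaves the size open), an estimate that stays within the scatter. For compound 3 the estimated value is 100000 nM, with an expected range from 40000 nM to 250000 nM.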

Compound 3, half-maximal inhibitory concentration: > 100000 nM
Compound 3: a limit, no number (the forecaster's own chance of this, stated with the estimate: 75%); the middle value lies on the limit itself.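

Compound 2 and compound 3 both come back as limits rather than numbers in this assay, so the step between them cannot be read: the limit of > 100000 nM in this assay, at which 2 of the 3 values shown sit. The compounds shown leave open whether 2,3-difluoro-4-nitrophenyl in place of 4,5-difluoro-2-nitrophenyl on an amine nitrogen shifts the value in this assay at all, and in which direction.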